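The compounds below may be only part of what the source reports. "The series", "measured", "known", "first", "only" and "open" are said of these compounds alone.

Measured so far:
Compound 1, `CN1CCN(S(=O)(=O)c2ccc(-c3ccc4c(Nc5ccc(OCc6cccc(F)c6)c(Cl)c5)nccc4c3)cc2)CC1`. In a toxicity assay on HepG2 cells (Homo sapiens) for cytotoxicity, read by MTT assay, with a stated time of 48 h (a lower number here means that less compound is tolerated, a higher number that more compound is tolerated), compound 1 gives only a limit of the assay, > 15 uM.
Compound 2, `CN1CCCN(S(=O)(=O)c2ccc(-c3ccc4c(Nc5ccc(OCc6cccc(F)c6)c(Cl)c5)nccc4c3)cc2)CC1`. In this assay compound 2 likewise gives only a limit, > 15 uM.
Compound 3, `CN1CCCN(S(=O)(=O)c2ccc(-c3ccc4c(Nc5ccc(OCc6cccc(F)c6)c(Cl)c5)nncc4c3)cc2)CC1`. In this assay compound 3 gives 3.4 uM.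

Compounds 1 and 2 share one core; compound 3 carries another, and the difference between the two cores is not broken down here. For the measured compounds named here, compound 3 is the only compound with a number; the other two sit at the limit of > 15 uM in this assay, at which 2 of the 3 values shown sit. From compound 2 to compound 1 the change is 4-methylpiperazin-1-yl in place of 4-methyl-1,4-diazepan-1-yl on a sulfonyl sulfur, and the step that the two limits leave unreadable from compound 2 to compound 1. Compound 4, `CN1CCN(S(=O)(=O)c2ccc(-c3ccc4c(Nc5ccc(OCc6cccc(F)c6)c(Cl)c5)nncc4c3)cc2)CC1`, is not yet measured; from compound 3 to compound 4 the same change is made: 4-methylpiperazin-1-yl in place of 4-methyl-1,4-diazepan-1-yl on a sulfonyl sulfur. Going by the values given here, the step from compound 3 to compound 4 is expected to be small, a 1.2-fold higher number from compound 3 to compound 4 (0.07 log units; within the scatter), resting on the one measured instance of this change, where compound 2 and compound 1 both stay at the limit of > 15 uM in this assay, at which 2 of the 3 values shown sit. Compound 4 is estimated at 4 uM, between 1.5 uM and 12 uM.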

Compound 4, half-maximal toxic concentration: > 15 uM
Compound 4 ended at the assay's limit (the forecaster's own chance of this, stated with the estimate: 25%); middle value at least 3.7-fold (0.57 log units) from the limit.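

In this assay, 4-methylpiperazin-1-yl in place of 4-methyl-1,4-diazepan-1-yl on a sulfonyl sulfur gives an at least 4.4-fold higher number from compound 3 to compound 4 (0.64 log units; beyond the scatter), so on this core the change is readable and beyond the scatter. The step is only a minimum, as compound 4 gives a limit of the assay, > 15 uM. On the core of compound 1 the same change cannot be read, so these compounds neither confirm nor refute that its size carries from one core to the other: the limit of > 15 uM in this assay, at which 3 of the 4 values shown sit.

From the compounds shown here alone, whether a morpholin-4-yl group or a dimethylamino group on the sulfonyl sulfur would behave like either ring stays open. So does the size of the step on the core of compound 1.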